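The source may hold more compounds than are shown below. What is called first, only, known or untested is meant among the compounds shown, and "the series" means these compounds.

Two members of this series have been measured in a functional assay on the whole organism (B cells) with Mus musculus as the target; on this read-out lower numbers stand for smaller maximal responses and higher numbers for larger maximal responses. Compound 1 `CC1OC(n2c(=O)n(C)c3c(O)nc(N)nc32)[C@H](O)[C@@H]1O` gives 0% in this assay. Compound 2 `Nc1nc(O)c2c(n1)n(C1OC(CO)[C@@H](O)[C@H]1O)c(=O)n2CC(O)CSc1ccccc1` gives 12% in this assay, the higher of the two numbers; compound 1 lies below it by a gap beyond the usual scatter. Compound 3 `NCC(O)Cn1c(=O)n(C2OC(CO)[C@@H](O)[C@H]2O)c2nc(N)nc(O)c21` has not yet been measured in this assay. It differs from compound 2 in one place: amino in place of phenylsulfanyl on a saturated chain carbon, two bonds along the chain from an oxygen on a saturated carbon. For the measured compounds named here, no pair of measured compounds that differ in one place is available, so the series itself gives no measured step to show how a change of this kind moves the read-out. Both measured numbers are low, and the expected step in this assay is small, a number 4 percentage points lower from compound 2 to compound 3 (within the scatter), with no direction that goes beyond the scatter. Compound 3 is therefore estimated to give 8% in this assay, within a range of 0% to 25%.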

Compound 3, largest response reached (reported as maximal response), in percent of the reference or control that the assay uses: 110%
The estimate for compound 3 lay 102 percentage points below the measured number; measured number above the stated range.
By their numbers in this assay, from the lowest: compound 1; then compound 2; then compound 3.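

In this assay, for the compounds shown here, amino in place of phenylsulfanyl on a saturated chain carbon, two bonds along the chain from an oxygen on a saturated carbon, gives a number 98 percentage points higher from compound 2 to compound 3 (beyond the scatter) and is the first step measured at a single place. The group at this position alone, with the rest of the structure unchanged, can therefore separate a small maximal response from a large one. Nothing available explains the size of this step.

The compounds shown leave open whether the rise follows from the presence of the amino group or from the loss of phenylsulfanyl; a hydroxyl, a dimethylamino group or a carboxylic acid at this place would separate the two. Also open, going by these compounds, is how a longer chain carrying the amine would read out.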